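The source may hold more compounds than are shown below. What is called first, only, known or untested is meant among the compounds shown, and "the series" means these compounds.

Among the measured compounds shown here, in a functional assay on K562 cells (Homo sapiens) for antiproliferative activity, read by sulforhodamine B assay, with a stated time of 72 h (on this read-out lower numbers stand for stronger inhibition and higher numbers for weaker inhibition), compound 1 (`S=C(NNc1nncc2ccccc12)Nc1ccccc1`) gives 76 nM and compound 2 (`COc1ccc(NC(=S)NNc2nncc3ccccc23)cc1`) gives 94 nM as the only other measured value, so the two lie within the scatter of each other. The move to compound 3 (`NC(=S)NNc1nncc2ccccc12`) is hydrogen in place of phenyl on an amide-type nitrogen and puts hydrogen in place of phenyl on an amide-type nitrogen. For the measured compounds named here, the one measured step is a 1.2-fold higher number from compound 1 to compound 2 (0.09 log units; within the scatter) and it keeps the phenyl, so it offers only weak guidance here. A move to a higher number in this assay is expected, with a 3.9-fold higher number from compound 1 to compound 3 (0.60 log units; beyond the scatter) as the estimated size. For compound 3 the estimated value is 300 nM with an expected range from 80 nM to 1500 nM in this measurement.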

Compound 3, half-maximal inhibitory concentration: 23 nM
Estimate against measurement, compound 3: 13-fold (1.12 log units) above; the measured number lies below the stated range.
By their numbers in this assay, from the lowest: compound 3; then compounds 1 and 2 (each within the scatter of the next).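

In this assay the change of phenyl to hydrogen on the amide-type nitrogen gives a 3.3-fold lower number from compound 1 to compound 3 (0.52 log units; beyond the scatter) and so goes beyond the scatter, which the methoxy step on that phenyl did not. The phenyl is therefore not required at this position for antiproliferative activity, and its loss lowers the number here. Nothing available accounts for this step. From the compounds shown here alone, what stays open is whether a methyl or a longer chain such as butyl on this nitrogen would keep the number of compound 3 23 nM or lose it.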